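A few compounds are considered here, and "the series" means these few. Any claim that something is new, unique, unknown or untested is made for them only; others in the source may bear on it.

Compound 1 `C=C/C=C\[C@H](C)[C@H](OC(N)=O)[C@@H](C)[C@H](O)[C@@H](C)C/C(C)=C\[C@H](C)[C@@H](OC(C)=O)[C@@H](C)/C=C\[C@@H](O)C[C@@H]1OC(=O)C(C)=C[C@H]1C` carries a single acetyl group on one of its hydroxyls. In a functional assay on A549 cells (Homo sapiens) for cytotoxicity (a higher number here means a weaker inhibitor, a lower number a stronger inhibitor), compound 1 gives 3130 nM, the higher of the two plain numbers recorded here. Among the measured compounds shown here, its nearest neighbour is compound 2 `C=C/C=C\[C@H](C)[C@H](OC(N)=O)[C@@H](C)[C@H](O)[C@@H](C)C/C(C)=C\[C@H](C)[C@@H](O)[C@@H](C)/C=C\[C@@H](O)C[C@@H]1OC(=O)C(C)=C[C@H]1C`, which in this assay gives 21.7 nM; the step of a 140-fold lower number from compound 1 to compound 2 (2.16 log units; beyond the scatter) is the only measured change that involves an acetyl group. Compound 3 `CCCC[C@H](C)[C@H](OC(N)=O)[C@@H](C)[C@H](O)[C@@H](C)CC(C)C[C@H](C)[C@@H](O)[C@@H](C)CC[C@@H](O)C[C@@H]1OC(=O)[C@H](C)[C@@H](O)[C@H]1C` in this assay gives > 8290 nM, which is a limit of the assay and not a number (the limit of > 8290 nM in this assay, at which 1 of the 3 values shown sits).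

Compound 4 `C=C/C=C\[C@H](C)[C@H](OC(N)=O)[C@@H](C)[C@H](OC(C)=O)[C@@H](C)C/C(C)=C\[C@H](C)[C@@H](OC(C)=O)[C@@H](C)/C=C\[C@@H](O)C[C@@H]1OC(=O)C(C)=C[C@H]1C` differs from compound 1 by acetyl in place of hydrogen on an oxygen on a saturated carbon. Since removing an acetyl lowered the number sharply, adding a second one is expected to raise it, and the expected step in this assay is a 4.8-fold higher number from compound 1 to compound 4 (0.68 log units; beyond the scatter). Compound 4 is therefore expected to give 15000 nM in this assay, with a range from 4000 nM to 60000 nM.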

Compound 4, half-maximal inhibitory concentration: > 7580 nM
Compound 4 was reported as a limit; the forecaster's own chance of this, stated with the estimate: 40%; the middle value is on the limit's open side.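

Acetyl in place of hydrogen on this oxygen on a saturated carbon gives an at least 2.4-fold higher number from compound 1 to compound 4 (0.38 log units; beyond the scatter). The earlier compounds shown here showed an acetyl effect at only one hydroxyl; this step shows that acetyl on a second hydroxyl also raises the number in this assay, even starting from the already acetylated compound 1. Compound 4 is recorded only as a limit of the assay: the limit of > 7580 nM in this assay, at which 1 of the 4 values shown sits.

On these data alone, how far the true value of compound 4 lies past that limit stays open. So does how a methyl ether or a longer acyl chain on this oxygen would read.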